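Swapping Phenylsulfanyl for Piperidinylmethyl on a Shared Core

The source may hold more compounds than are shown below. What is called first, only, known or untested is meant among the compounds shown, and "the series" means these compounds.

Of the compounds shown here, two have so far been measured in a functional assay on the whole organism with Mus musculus as the target; a lower number here means that less compound is needed, a higher number that more compound is needed for the effect. Compound 1 `Cc1c(N)cc2c(c1C)OC(C)(C)C2` gives 24.4 mg/kg in this assay. Compound 2 `Cc1c(C)c2c(c(C)c1N)CC(C)(CSc1ccccc1)O2` gives 24.7 mg/kg in this assay, the higher of the two numbers, but its gap to compound 1 lies within the scatter of repeated measurements, so the two compounds cannot be told apart on these data.

Compound 3 `Cc1c(C)c2c(c(C)c1N)CC(C)(CCN1CCCCC1)O2` has not yet been measured. It differs from compound 2 in a single place: (piperidin-1-yl)methyl in place of phenylsulfanyl on a saturated chain carbon bound to a saturated ring carbon. The phenylsulfanyl group leaves and a (piperidin-1-yl)methyl group enters, both of seven heavy atoms, each with one hydrogen-bond acceptor and no net charge, on a saturated chain carbon bound to a saturated ring carbon.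

Within the data shown here, no step between measured compounds is known, so no size can be derived from the data for this exchange. The account therefore expects the step from compound 2 to compound 3 to be a 1.0-fold higher number from compound 2 to compound 3 (0.01 log units; within the scatter), that is, no change beyond the scatter, with a wide band of uncertainty. Compound 3 is estimated at 25 mg/kg in this assay, within a range from 8 mg/kg to 80 mg/kg.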

Compound 3, dose for 50% inhibition: 18.4 mg/kg
Estimate against measurement, compound 3: 1.4-fold (0.13 log units) above; low and high end bracket the measured number.
By their numbers in this assay, from the lowest: compounds 3, 1 and 2 (each within the scatter of the next).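

In this assay, among these compounds, the exchange of phenylsulfanyl for (piperidin-1-yl)methyl on a saturated chain carbon bound to a saturated ring carbon gives a 1.3-fold lower number from compound 2 to compound 3 (0.13 log units; within the scatter), and this is the first step at this place that can be read from the data. It shows that two quite different groups can occupy this place with no change beyond the scatter: a six-membered aromatic ring of carbon only, attached through sulfur, leaves, and a six-membered non-aromatic ring with 1 hetero atom enters, while the heavy-atom and acceptor counts stay the same. No independent measurement on these compounds bears on why the whole-organism result stays within the scatter across this exchange.

This single step leaves open whether any group at this place can move the number beyond the scatter, for instance a morpholine ring, a simple dimethylamino group, a carboxylic acid or a longer chain carrying the piperidine. It also leaves open whether the same exchange would behave alike on a core with a different substitution.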